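This account rests on a few compounds, and the source may have more. Where it says the series, first, only, none or still open, it means among the compounds named here.

Measured in a functional assay on HepG2 cells (Homo sapiens) for cytotoxicity, read by MTT assay, with a stated time of 72 h; on this read-out higher numbers stand for weaker inhibition and lower numbers for stronger inhibition:

- compound 1 `COc1ccc(/C=N/NC(=O)Nc2cc3c(Nc4ccc(F)c(Cl)c4)ncnc3cc2O[C@H]2CCOC2)cc1` gives 28800 nM
- compound 2 `COc1cc2ncnc(Nc3ccc(F)c(Cl)c3)c2cc1NC(=O)N/N=C/c1ccc(F)cc1Cl` gives 29200 nM
- compound 3 `COc1cc2ncnc(Nc3ccc(F)c(Cl)c3)c2cc1NC(=O)N/N=C/c1cc(C(C)(C)C)c(O)c(C(C)(C)C)c1` gives 26800 nM

These three values lie within the usual scatter of one another, so compound 2 at 29200 nM cannot be separated from either of the other two. This holds even though the group on the carbon with a double bond to nitrogen is not the same in any two of them.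

Compound 4 `CCN(CC)c1ccc(/C=N/NC(=O)Nc2cc3c(Nc4ccc(F)c(Cl)c4)ncnc3cc2OC)c(O)c1` has not yet been measured. It departs from compound 2 in one place, with 4-(diethylamino)-2-hydroxyphenyl in place of 2-chloro-4-fluorophenyl on a carbon with a double bond to nitrogen.

Within the data shown here, no measured compound carries the 4-(diethylamino)-2-hydroxyphenyl group, and no single-place step has been measured in this assay, so the only guide is the narrow spread of the three values. A large change would therefore be a surprise, although the range has to stay wide. The expected size of the change is small, leaning slightly towards a lower number and staying within the scatter, as the estimated 1.5-fold lower number from compound 2 to compound 4 (0.16 log units; within the scatter) shows.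

The estimate for compound 4 is 20000 nM, with an expected range from 8000 nM to 40000 nM.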

Compound 4, half-maximal inhibitory concentration: 29300 nM
The estimate for compound 4 lay 1.5-fold (0.17 log units) below the measured number, within the range that was stated.
By their numbers in this assay, from the lowest: compounds 3, 1, 2 and 4 (each within the scatter of the next).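

In this assay, among these compounds, the replacement of 2-chloro-4-fluorophenyl by 4-(diethylamino)-2-hydroxyphenyl on a carbon with a double bond to nitrogen gives the first single-place step in this set, a 1.0-fold higher number from compound 2 to compound 4 (0.00 log units; within the scatter), and that step lies within the scatter. Among the compounds shown here, the earlier compounds showed only that three different groups went with values that could not be separated, whereas this direct comparison holds the rest of the structure fixed and shows that a larger entering group, with a hydrogen-bond donor and hydrogen-bond acceptors and with neither chlorine nor fluorine, leaves the number where it was in this cytotoxicity read-out. Nothing available here explains why this exchange leaves the value in place.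

From the compounds shown here alone, what remains open is whether any group at this position can move the number beyond the scatter, for instance a carboxylic acid, a piperazine or a non-aromatic cyclohexyl in place of the substituted phenyl. Going by these compounds, it is also open whether a pyridine ring would behave as the two phenyl groups in this step do.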